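Moving a chlorine on the benzyl group of compound 3

This account rests on a few compounds, and the source may have more. Where it says the series, first, only, none or still open, it means among the compounds named here.

Measured compounds:
compound 1 `CC1=C(C(=O)Nc2ccc(F)cc2)C(c2ccc([N+](=O)[O-])cc2)N=C(SCc2ccccc2Cl)N1` 13.9%
compound 2 `CC1=C(C(=O)Nc2ccc(F)cc2)C(c2ccc([N+](=O)[O-])cc2)N=C(SCc2cccc(Cl)c2)N1` 12.9%
compound 3 `CC1=C(C(=O)Nc2ccc(Br)cc2)C(c2ccc(Cl)cc2Cl)N=C(SCc2ccccc2Cl)N1` 20.6%

Of the compounds shown here, three have been tested in a functional assay on the whole organism (artery, strain albino) with Rattus norvegicus as the target, with a stated time of 720 min, at a dose of 10 mg/kg by the oral route; on this read-out lower numbers stand for less inhibition and higher numbers for more inhibition at the one dose given (going by the name of the read-out). Compound 1 gives 13.9% and compound 2 gives 12.9%. Between them lies one change, (3-chlorophenyl in place of 2-chlorophenyl on a saturated chain carbon bound to a sulfur), and the step it made is a number 1 percentage points lower from compound 1 to compound 2 (within the scatter). Compound 3 differs from compound 1 in a way not broken down here. In this assay compound 3 gives 20.6%, and its gaps to compound 1 and compound 2 are within the scatter.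

Compound 4 `CC1=C(C(=O)Nc2ccc(Br)cc2)C(c2ccc(Cl)cc2Cl)N=C(SCc2cccc(Cl)c2)N1` is not yet measured. It differs from compound 3 by 3-chlorophenyl in place of 2-chlorophenyl on a saturated chain carbon bound to a sulfur, the same change as from compound 1 to compound 2. Because that earlier step was a number 1 percentage points lower from compound 1 to compound 2 (within the scatter), the step from compound 3 to compound 4 is expected to be about a number 1 percentage points lower from compound 3 to compound 4 (within the scatter) in this assay. Compound 4 is therefore estimated at 19.6%, with a range from 10% to 29%.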

Compound 4, a percentage reported as inhibition, in the whole organism at one dose (the size of the read-out at that dose, not a potency): 11.3%
Compound 4: middle estimate off by 8.3 percentage points, on the high side; the range from low to high includes it.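

In this assay, the change from 2-chlorobenzyl to 3-chlorobenzyl came out as a number 9.3 percentage points lower from compound 3 to compound 4 (within the scatter). Set beside the earlier step, the change reads alike on the two cores as far as this read-out can tell: the same change on two cores in this assay, a number 1 percentage points lower (within the scatter) from compound 1 to compound 2 and a number 9.3 percentage points lower (within the scatter) from compound 3 to compound 4, 8.3 percentage points apart, within the scatter of two such steps. This shows no sign that the core alters the step, but it does not show that the step carries over in a fixed size: each core supplies a single pair, at one dose, and neither step stands clear of the scatter. The compounds shown leave open how the read-out responds when a longer alkyl chain or an amine takes the place of the chlorobenzyl group on the sulfur.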